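The compounds below may be only part of what the source reports. "The series", "measured", "known", "first", "only" and "open" are said of these compounds alone.

Working notes on the series. Among the measured compounds shown here, the two measured members share one core: compound 1 `O=C(COc1ccc(C(=O)/C=C/c2ccccc2Br)cc1)N[C@H]1CCOC1=O` and compound 2 `COc1ccccc1/C=C/C(=O)c1ccc(OCC(=O)N[C@H]2CCOC2=O)cc1`. For the measured compounds named here, in a functional assay on PC-3 cells (Homo sapiens) for antiproliferative activity, read by MTT assay, with a stated time of 72 h (on this read-out higher numbers stand for weaker inhibition and lower numbers for stronger inhibition), compound 1 gives 3260 nM, and in this assay compound 2 gives 7240 nM; the single step recorded, a 2.2-fold higher number from compound 1 to compound 2 (0.35 log units; beyond the scatter), comes from methoxy in place of bromo on an aromatic carbon. Going by the values given here, compound 2 therefore stands at the highest of the two numbers, with compound 1 as its only neighbour.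

Compound 3 `O=C(COc1ccc(C(=O)/C=C/c2cccc(Br)c2)cc1)N[C@H]1CCOC1=O` is not yet measured. It differs from compound 2 by 3-bromophenyl in place of 2-methoxyphenyl on a double-bonded chain carbon bound to a double-bonded chain carbon. Among the compounds with values here, the only step that bears on it is a 2.2-fold higher number from compound 1 to compound 2 (0.35 log units; beyond the scatter), which went the other way when bromo was exchanged for methoxy; compound 3 brings bromo back, though as 3-bromophenyl, not the same group as in compound 1. A modest step down is expected, a 2.1-fold lower number from compound 2 to compound 3 (0.32 log units; beyond the scatter), roughly undoing that change. Compound 3 is estimated at 3500 nM, within 1500 nM to 8000 nM.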

Compound 3, half-maximal inhibitory concentration: 7890 nM
Compound 3: the middle estimate sits 2.3-fold (0.35 log units) below what was measured, and the stated range covers the measured number.
By their numbers in this assay, from the lowest: compound 1; then compounds 2 and 3 (each within the scatter of the next).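

In this assay, 3-bromophenyl in place of 2-bromophenyl on a double-bonded chain carbon bound to a double-bonded chain carbon gives a 2.4-fold higher number from compound 1 to compound 3 (0.38 log units; beyond the scatter), so the presence of bromo alone does not secure the lower number seen for compound 1, and these two bromophenyl groups are not interchangeable here. The exchange of 2-methoxyphenyl for 3-bromophenyl gives a 1.1-fold higher number from compound 2 to compound 3 (0.04 log units; within the scatter), so these two groups cannot be told apart in this read-out, although only 2-methoxyphenyl carries a hydrogen-bond acceptor. Nothing available on these compounds explains either step.

The compounds shown leave open how a 2-chlorophenyl or an unsubstituted phenyl group would read at this chain carbon, and whether 3-methoxyphenyl would match 3-bromophenyl. From the compounds shown here alone, all three share the rest of the core, so the part played by that remainder also stays open.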